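The source may hold more compounds than are shown below. What is called first, only, known or untested is meant among the compounds shown, and "the series" means these compounds.

Among the measured compounds shown here, in a functional assay on L02 cells (Homo sapiens) for inhibition (on this read-out higher numbers stand for weaker inhibition and lower numbers for stronger inhibition), the three compounds tested so far all sit at the weak end of the scale. Compound 1 `O=C(CC(CC(=O)NC1Cc2ccccc2C1)c1ccccc1)NCCN1CCCCC1` reads > 100000 nM, which is a limit of the assay and not a number. Compound 3 `CCN(C(=O)CC(CC(=O)NCCN1CCCC1)c1ccccc1)C1Cc2ccccc2C1` reads > 100000 nM, and this too is a limit and not a number. For the measured compounds named here, compound 2 `CCN(C(=O)CC(CC(=O)NCCN1CCCCC1)c1ccc(Cl)cc1)C1Cc2ccccc2C1` is the only one with a true number, at 84200 nM. The overall picture is the limit of > 100000 nM in this assay, at which 2 of the 3 values shown sit.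

Compound 4 `CCN(C(=O)CC(CC(=O)NCCN1CCCCC1)c1ccccc1)C1Cc2ccccc2C1` differs from compound 3 in one place: piperidin-1-yl in place of pyrrolidin-1-yl on a saturated chain carbon, two bonds along the chain from an amide-type nitrogen. In words, piperidin-1-yl stands in place of pyrrolidin-1-yl on a saturated chain carbon, two bonds along the chain from an amide-type nitrogen. Going by the values given here, no measured pair shows what this change does in this assay, so no step beyond the usual scatter is expected, and no direction can be named. The expected step of an at least 1.1-fold lower number from compound 3 to compound 4 (0.04 log units; that floor lies within the scatter) is therefore a small one. For compound 4 the estimate is 90000 nM, with an expected range of 45000 nM to 180000 nM, and the assay may well report only a limit.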

Compound 4, half-maximal inhibitory concentration: > 100000 nM
Compound 4: only a limit was reported; the forecaster's own chance of this, stated with the estimate: 60%; at least 1.1-fold (0.04 log units) between middle value and limit.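

In this assay compound 4 gives > 100000 nM, which is a limit and not a number. Hydrogen in place of chloro on an aromatic carbon gives an at least 1.1-fold higher number from compound 2 to compound 4 (0.07 log units; that floor lies within the scatter), so this pair shows no clear gain or loss from the chloro group, although the true step could be larger. The steps to compound 4 from compound 3 and from compound 1 cannot be read, because both ends of each step are limits: the limit of > 100000 nM in this assay, at which 3 of the 4 values shown sit.

So whether piperidin-1-yl and pyrrolidin-1-yl differ at all in this position, or whether the ethyl on the amide-type nitrogen matters, stays open. Also open, as far as these compounds go, is whether another group in that place, such as morpholin-4-yl or a dimethylamino group, would bring a reading clear of the limit.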